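Removing the chloro from a trifluoromethylphenyl substituent

A few compounds are considered here, and "the series" means these few. Any claim that something is new, unique, unknown or untested is made for them only; others in the source may bear on it.

Measured so far:
compound 1, `CCCS(=O)(=O)Nc1ccc(F)c(C(=O)c2n[nH]c3ncc(-c4ccccc4F)cc23)c1F`, 2% in an assay for binding affinity to dual specificity mitogen-activated protein kinase kinase 4 (Homo sapiens), read by KINOMEscan, tested at 100 nM; a higher number here means a weaker effect of the compound at the concentration tested, a lower number a stronger effect
compound 2, `CCCS(=O)(=O)Nc1ccc(F)c(C(=O)c2n[nH]c3ncc(-c4ccc(Cl)c(C(F)(F)F)c4)cc23)c1F`, 15% in this assay

Within the data shown here, compound 2 gives the highest of the two numbers measured so far in this assay; its nearest neighbour is compound 1, which sits a number 13 percentage points higher from compound 1 to compound 2 (beyond the scatter). The two differ only in the aryl substituent on the shared core, 4-chloro-3-(trifluoromethyl)phenyl in compound 2 in place of 2-fluorophenyl in compound 1.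

Compound 3, `CCCS(=O)(=O)Nc1ccc(F)c(C(=O)c2n[nH]c3ncc(-c4cccc(C(F)(F)F)c4)cc23)c1F`, is the next compound to be measured in this assay. It differs from compound 2 as follows: hydrogen in place of chloro on an aromatic carbon. Among the measured compounds shown here, the only measured step that bears on this is the one from compound 1 to compound 2, which is modest and runs in the direction of a higher number. Compound 3 keeps the trifluoromethyl of compound 2 but loses the chloro, so it sits between the two measured compounds in structure; the step of a number 6 percentage points lower from compound 2 to compound 3 (within the scatter) is expected to be a small one, toward a lower number, within or near the scatter. Compound 3 is therefore estimated at 9%, with a range from 2% to 25%.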

Compound 3, a percentage reported as activity, at one concentration (the size of the read-out at that concentration, not a potency): 57%
Beside the measured number, compound 3's estimate is 48 percentage points below it; measured number above the stated range.
By their numbers in this assay, from the lowest: compound 1; then compound 2; then compound 3.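

In this assay, hydrogen in place of chloro on the aromatic carbon ortho to the trifluoromethyl group gives a number 42 percentage points higher from compound 2 to compound 3 (beyond the scatter), so the loss of one heavy atom at this place weighs far more than the earlier pair could show. The 3-(trifluoromethyl)phenyl group in place of 2-fluorophenyl gives a number 55 percentage points higher from compound 1 to compound 3 (beyond the scatter), while the 4-chloro-3-(trifluoromethyl)phenyl group in that same swap gave only a number 13 percentage points higher from compound 1 to compound 2 (beyond the scatter) on the same read-out. Among these three compounds, then, the trifluoromethyl group does not set the number by itself: the two compounds that carry it lie far apart, and the one that also keeps the chloro stands closer to compound 1. Nothing at hand gives a reason for this. The compounds shown leave open whether a 4-chlorophenyl group, with the chloro and no trifluoromethyl, would give a low number, and so whether the chloro works alone or only together with the trifluoromethyl. They also leave open whether a methyl, a fluoro or a methoxy on that aromatic carbon would match the chloro.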